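Mouse liver microsome clearance: compound 2 toward compound 4

A few compounds are considered here, and "the series" means these few. Any claim that something is new, unique, unknown or untested is made for them only; others in the source may bear on it.

Measured so far in an in vitro ADME assay on microsomes from liver (Mus musculus) for pharmacokinetics, read by LC-MS, with a stated time of 10 min, tested at 1 uM; on this read-out higher numbers stand for fast clearance and lower numbers for slow clearance:
compound 1, `Cc1ccc(NC(=O)[C@H]2CN(C)C[C@@H]2c2ccc(/C=C/C(=O)Nc3ccccc3N)cc2)cc1`: 62 mL/min/kg
compound 2, `CN1C[C@H](C(=O)Nc2ccc(C(F)(F)F)cc2)[C@@H](c2ccc(/C=C/C(=O)Nc3ccccc3N)cc2)C1`: 23 mL/min/kg
compound 3, `Cc1cc(NC(=O)[C@H]2CN(C)C[C@@H]2c2ccc(/C=C/C(=O)Nc3ccccc3N)cc2)ccc1Cl`: 65 mL/min/kg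

Compound 2 gives the lowest number of the three, set apart from compound 1 by a 2.7-fold lower number from compound 1 to compound 2 (0.43 log units; beyond the scatter) and from compound 3 by a 2.8-fold higher number from compound 2 to compound 3 (0.45 log units; beyond the scatter); compounds 1 and 3 lie within the scatter of each other. Compound 4, `CN1C[C@H](C(=O)Nc2cccnc2)[C@@H](c2ccc(/C=C/C(=O)Nc3ccccc3N)cc2)C1`, is not yet tested in this assay. Its change from compound 2 is pyridin-3-yl in place of 4-(trifluoromethyl)phenyl on an amide-type nitrogen. For the measured compounds named here, both measured steps that connect 4-(trifluoromethyl)phenyl on the amide-type nitrogen to another group run toward the higher numbers by a modest amount, so a modest rise is expected here too, although no measured compound carries a ring with a hetero atom at this place. Compound 4 is therefore expected to give 45 mL/min/kg (range 25 mL/min/kg to 85 mL/min/kg), an expected step of a 2.0-fold higher number from compound 2 to compound 4 (0.29 log units; within the scatter).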

Compound 4, clearance: 41 mL/min/kg
Estimate against measurement, compound 4: 1.1-fold (0.04 log units) above, within the range that was stated.
By their numbers in this assay, from the lowest: compounds 2, 4, 1 and 3 (each within the scatter of the next, the first and the last beyond it).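

In this assay, for the compounds shown here, pyridin-3-yl is the first ring with a hetero atom on the amide-type nitrogen, and it stays within the scatter of all three carbon-only aryl groups (a 1.8-fold higher number from compound 2 to compound 4 (0.25 log units; within the scatter); a 1.6-fold lower number from compound 3 to compound 4 (0.20 log units; within the scatter); a 1.5-fold lower number from compound 1 to compound 4 (0.18 log units; within the scatter)). Compound 4 therefore cannot be separated from any of them, although compound 2 and compound 3 remain apart beyond the scatter. Nothing available explains these values.

On these data alone, whether a pyridin-4-yl ring, a piperidine ring or a carboxylic acid on the phenyl ring would read the same at this nitrogen stays open. Changes elsewhere on the shared core also stay open.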